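The compounds below may be only part of what the source reports. "The series", "measured", "known", "first", "only" and "open" are said of these compounds alone.

In a functional assay on A549 cells (Homo sapiens) for cytotoxicity (on this read-out higher numbers stand for an effect only at larger amounts of compound and lower numbers for an effect already at smaller amounts), compound 1 `COc1ccc(/C=C/c2cc(OC)c(OC(C)=O)c(OC)c2)cc1` gives 16.4 uM. Compound 2 `COc1cc(/C=C\c2ccc(C(C)(C)C)cc2)cc(OC)c1OC` gives 1.02 uM, the lower of the two numbers, so it acts at smaller amounts, and the gap between them lies beyond the usual scatter. For the measured compounds named here, with only two measured compounds, this places compound 2 at the better end of a very short scale. Those two compounds differ in more than one place, so their gap cannot be pinned on any single change.

Compound 3 `COc1cc(/C=C\c2ccc(C(C)C)cc2)cc(OC)c1OC` differs from compound 2 in a single small change: hydrogen in place of methyl on a saturated chain carbon bound to an aromatic carbon and two saturated chain carbons. Here hydrogen stands in place of methyl on a saturated chain carbon bound to an aromatic carbon and two saturated chain carbons, which turns tert-butyl into isopropyl. Going by the values given here, no measured pair shows what this change does, so the expectation rests on how small it is. From the compounds shown here alone, no step beyond the scatter is expected in this assay, and the direction remains open. The expected change is a 1.1-fold lower number from compound 2 to compound 3 (0.05 log units; within the scatter). For compound 3 the estimated value is 0.9 uM, with an expected range from 0.3 uM to 3 uM.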

Compound 3, concentration for half-maximal effect: 6.6 uM
Beside the measured number, compound 3's estimate is 7.3-fold (0.87 log units) below it; the measured number lies above the stated range.
By their numbers in this assay, from the lowest: compound 2; then compound 3; then compound 1.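

In this assay, for the compounds shown here, the change from tert-butyl to isopropyl, with hydrogen in place of methyl on a saturated chain carbon bound to an aromatic carbon and two saturated chain carbons, gives the first step that can be read in one place: a 6.5-fold higher number from compound 2 to compound 3 (0.81 log units; beyond the scatter). This shows that the place is not indifferent to a small edit: losing one methyl, a single carbon that brings no hydrogen-bond donors, no hydrogen-bond acceptors and no net charge, moves the number beyond the scatter, towards an effect only at larger amounts of compound. Nothing measured here accounts for the step, so it records what happens and not why.

From the compounds shown here alone, one step gives two points and no trend, so it remains open how an ethyl group, a lone methyl, a longer chain, trifluoromethyl, an amine or a carboxylic acid would behave at this place. Going by these compounds, it also remains open whether the change from tert-butyl to isopropyl would give a step of similar size and direction on a different core.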